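Replacing the Group on the Carbonyl Carbon of Compound 1

The source may report more compounds than this note shows. Statements on the series, on what has been measured and on what is new or still open speak of the compounds shown alone.

In an ADME assay on microsomes from liver (Mus musculus) for metabolic stability, with a stated time of 10 min (on this read-out higher numbers stand for a more stable compound and lower numbers for a less stable compound), compound 1 `O=C(O)C12CCC(C(=O)N3CC[C@](c4ccc(C(F)(C(F)(F)F)C(F)(F)F)cc4)(S(=O)(=O)c4ccc(F)cc4)C3)(CC1)CC2` gives 73%. Compound 2 `CS(=O)(=O)C1CCC(C(=O)N2CC[C@](c3ccc(C(F)(C(F)(F)F)C(F)(F)F)cc3)(S(=O)(=O)c3ccc(F)cc3)C2)CC1` gives 69%; "not determined" (no result reported) (2 entries), which lies within the usual scatter of the value for compound 1. Compound 3 `O=C(C1CCS(=O)(=O)CC1)N1CC[C@](c2ccc(C(F)(C(F)(F)F)C(F)(F)F)cc2)(S(=O)(=O)c2ccc(F)cc2)C1` keeps the core of compound 1 but carries 1,1-dioxothian-4-yl on the carbonyl carbon: a group of 8 heavy atoms (5 carbon, 2 oxygen, 1 sulfur; one six-membered non-aromatic ring with 1 hetero atom) in place of a group of 11 heavy atoms (9 carbon, 2 oxygen; 2 six-membered non-aromatic rings of carbon only), on a carbonyl carbon. Going by the values given here, no measured step shows the effect of this change, so the expectation rests only on these two close values. A small step of a number 3 percentage points lower from compound 1 to compound 3 (within the scatter) is expected, staying within the usual scatter. Compound 3 is estimated at 70%, with an expected range of 52% to 85%.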

Compound 3, percent of the compound remaining: 96%
Compound 3: middle estimate off by 26 percentage points, on the low side, and the stated range ends below it.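

At this carbonyl carbon, the group is not interchangeable in this assay: putting 1,1-dioxothian-4-yl in place of the group of compound 1 gives a number 23 percentage points higher from compound 1 to compound 3 (beyond the scatter). Going by these compounds alone, this is the first measured step at this position, and it shows that a smaller group with one ring can read higher here. Nothing at hand explains the step.

The change alters ring count, hetero atom and hydrogen-bond donor together, so the compounds shown cannot separate these features. They also leave open how a piperidine ring carrying an amine, or a longer chain, would read at this carbonyl carbon.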